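Swapping the allyl group on a compound at the limit

The source may report more compounds than this note shows. Statements on the series, on what has been measured and on what is new or still open speak of the compounds shown alone.

In an ADME assay on CCRF-CEM cells (Homo sapiens) for cytotoxicity, with a stated time of 5 days (on this read-out higher numbers stand for weaker inhibition and lower numbers for stronger inhibition), compound 2 (`C=CCNc1nc(N)nc2c1ncn2[C@H]1C[C@H](N=[N+]=[N-])[C@@H](CO)O1`) gives > 100000 nM as its result, which is a limit of the assay and not a number. Compound 1 (`C=CCNc1ncnc2c1ncn2[C@H]1C[C@H](N=[N+]=[N-])[C@@H](CO)O1`) gives > 100000 nM as its result, again only a limit. Compound 3 (`COc1nc(OC)c2ncn([C@H]3C[C@H](N=[N+]=[N-])[C@@H](CO)O3)c2n1`) gives > 100000 nM as its result, and that too is a limit. The picture so far is the limit of > 100000 nM in this assay, at which 3 of the 3 values shown sit, and no order among these compounds can be read, so compound 2 has no number to stand on.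

The next structure is compound 4 (`CC(CO)Nc1nc(N)nc2c1ncn2[C@H]1C[C@H](N=[N+]=[N-])[C@@H](CO)O1`), still unmeasured. The change is 1-(hydroxymethyl)ethyl in place of allyl on a nitrogen on an aromatic ring and it means that 1-(hydroxymethyl)ethyl takes the place of allyl on a nitrogen on an aromatic ring. Among the compounds with values here, the one measured step is a step that the two limits leave unreadable from compound 1 to compound 2 and it concerns an amino group rather than this chain, so it offers no size to carry over.

No change that can be read is expected, since compound 2 reports > 100000 nM as a limit. The expected step is a number no higher from compound 2 to compound 4 (the limit leaves the size open) and it is only an estimate. For compound 4 the estimate is 100000 nM with an expected range from 40000 nM to 250000 nM and the result may well be a limit again.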

Compound 4, half-maximal inhibitory concentration: > 100000 nM
Compound 4 gave a limit, no number; the forecaster's own chance of this, stated with the estimate: 85%; the middle value sits exactly at the limit.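

In this assay compound 4 gives > 100000 nM, which is a limit of the assay and not a number. Compound 2 sits at that same limit, so no step from compound 2 to compound 4 can be read, and the picture stays as it was: the limit of > 100000 nM in this assay, at which 4 of the 4 values shown sit.

The compounds shown leave open whether 1-(hydroxymethyl)ethyl in place of allyl changes the read-out at all.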